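The source may report more compounds than this note shows. Statements on the series, on what has been measured and on what is new or still open speak of the compounds shown alone.

In a functional assay on NCI-H460 cells (Homo sapiens) for cytotoxicity, read by MTT assay, with a stated time of 72 h (a lower number here means a stronger inhibitor, a higher number a weaker inhibitor), three compounds have been measured so far.

- compound 1 `CC(C)(C)c1[nH]cnc1/C=c1\[nH]c(=O)/c(=C/c2cccc(C(=O)c3ccc(F)cc3)c2)[nH]c1=O` gives 3.8 nM
- compound 2 `CC(C)c1[nH]cnc1/C=c1\[nH]c(=O)/c(=C/c2cccc(C(=O)c3ccc(F)cc3)c2)[nH]c1=O` gives 3.2 nM
- compound 3 `O=c1[nH]/c(=C\c2nc[nH]c2C2CC2)c(=O)[nH]/c1=C\c1cccc(Oc2ccc(F)cc2)c1` gives 15.2 nM

Compound 3 has the highest number of the three, and the values of the other two lie beyond the scatter from it. Compound 4 `O=C(c1ccc(F)cc1)c1cccc(/C=c2\[nH]c(=O)/c(=C/c3nc[nH]c3C3CC3)[nH]c2=O)c1` differs from compound 3 in one group only: (4-fluorophenyl)carbonyl in place of 4-fluorophenoxy on an aromatic carbon with (4-fluorophenyl)carbonyl in place of 4-fluorophenoxy on an aromatic carbon.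

Among the measured compounds shown here, no measured step covers this swap directly. For the measured compounds named here, the only step available, a 1.2-fold lower number from compound 1 to compound 2 (0.07 log units; within the scatter), is hydrogen in place of methyl on a saturated chain carbon, and it stays within the scatter. Its bearing is indirect: compound 1 and compound 2 both carry the incoming (4-fluorophenyl)carbonyl group and sit close together. They also differ from compound 3 elsewhere, so the gap cannot be credited to the swap alone.

A lower number beyond the scatter is therefore expected in this assay for this swap, although its size remains uncertain. The expected change is a 3.4-fold lower number from compound 3 to compound 4 (0.53 log units; beyond the scatter) and it rests on these two neighbours. For compound 4 the estimate is 4.5 nM, expected to fall within 1.8 nM to 11 nM on repeated measurement.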

Compound 4, half-maximal inhibitory concentration: 2.8 nM
For compound 4 the middle estimate is 1.6-fold (0.21 log units) above the measured one; low and high end bracket the measured number.
By their numbers in this assay, from the lowest: compounds 4, 2 and 1 (each within the scatter of the next); then compound 3.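

In this assay, among the compounds shown here, the exchange at this aromatic carbon, meta to a large group, now has a direct reading: (4-fluorophenyl)carbonyl in place of 4-fluorophenoxy gives a 5.4-fold lower number from compound 3 to compound 4 (0.73 log units; beyond the scatter), a step beyond the scatter that the earlier compounds could suggest only indirectly, as they also differ elsewhere. With (4-fluorophenyl)carbonyl held in place, the alkyl group at the other varied aromatic carbon makes no difference beyond the scatter among these three compounds: cyclopropyl in place of isopropyl gives a 1.1-fold lower number from compound 2 to compound 4 (0.06 log units; within the scatter), and cyclopropyl in place of tert-butyl gives a 1.4-fold lower number from compound 1 to compound 4 (0.13 log units; within the scatter). Nothing available here explains the effect of the exchange in this assay.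

Among the compounds shown, 4-fluorophenoxy appears only with cyclopropyl, so it remains open whether the same step would appear with isopropyl or tert-butyl at the other site. From the compounds shown here alone, it is also open how the number would respond to an amine or a methylene in place of the carbonyl, to unsubstituted phenyl in place of 4-fluorophenyl, or to a methyl or a longer chain in place of the cyclopropyl.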